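A few compounds are considered here, and "the series" means these few. Any claim that something is new, unique, unknown or untested is made for them only; others in the source may bear on it.

Measured so far:
Compound 1 `Nc1scc(CN2CCN(c3ccc(Cl)cc3Cl)CC2)c1C(=O)c1ccc(Cl)cc1` — a functional assay on CHO cells with adenosine receptor A1 (Homo sapiens) as the target, read by cAMP accumulation and immunoassay, with a stated time of 6 min, tested at 0.01 uM (a higher number here means a weaker effect of the compound at the concentration tested, a lower number a stronger effect), 2%
Compound 2 `Nc1scc(CN2CCN(c3ccccc3F)CC2)c1C(=O)c1ccc(Cl)cc1` — this assay 2.1%

Among the compounds with values here, compound 2 and compound 1 lie within the scatter of each other in this assay, so the two numbers cannot be told apart, and compound 2 is one of only two compounds measured. Within the data shown here, the single measured step bears directly on what follows: a number 0.1 percentage points higher from compound 1 to compound 2 (within the scatter), a change on the same ring nitrogen that the next step touches.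

Compound 3 `Nc1scc(CN2CCN(c3cc(Cl)ccc3Cl)CC2)c1C(=O)c1ccc(Cl)cc1` is not yet measured. It differs from compound 2 in one place: 2,5-dichlorophenyl in place of 2-fluorophenyl on an amine nitrogen in a ring. Among the measured compounds shown here, because the only measured step on this nitrogen, a number 0.1 percentage points higher from compound 1 to compound 2 (within the scatter), stayed within the scatter when a dichlorophenyl was exchanged for a 2-fluorophenyl, the return to a dichlorophenyl, now 2,5-dichlorophenyl, is expected to bring no step beyond the scatter, a number 0.9 percentage points higher from compound 2 to compound 3 (within the scatter). Compound 3 is therefore estimated to give 3% in this assay, with a range from -5% to 13%.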

Compound 3, a percentage reported as activity, at one concentration (the size of the read-out at that concentration, not a potency): 13%
The estimate for compound 3 lay 10 percentage points below the measured number, within the range that was stated.
By their numbers in this assay, from the lowest: compounds 1 and 2 (each within the scatter of the next); then compound 3.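

In this assay, the group on the amine nitrogen in the ring proved not to be indifferent to change: the exchange of 2-fluorophenyl for 2,5-dichlorophenyl gave a number 10.9 percentage points higher from compound 2 to compound 3 (beyond the scatter), so the effect at the concentration tested became weaker, whereas the earlier exchange at this nitrogen had stayed within the scatter. The comparison of the two dichlorophenyl groups is the more telling one, since their names differ only in where one chlorine stands, yet 2,5-dichlorophenyl in place of 2,4-dichlorophenyl gave a number 11 percentage points higher from compound 1 to compound 3 (beyond the scatter), which shows that the chlorine pattern on this ring can matter and not merely the presence of two chlorines. Nothing available explains why the 2,5-dichlorophenyl group behaves differently.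

As far as these compounds go, it remains open whether a plain phenyl, a 2,5-difluorophenyl or a 2,5-dimethoxyphenyl on this nitrogen would fall with compound 1 and compound 2 or with compound 3. The read-out also comes from a single concentration, so it leaves open how far this modest step would carry over into a difference in potency.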